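Removing the ring fluorine of compound 2: expected cytotoxicity

A few compounds are considered here, and "the series" means these few. Any claim that something is new, unique, unknown or untested is made for them only; others in the source may bear on it.

Going by the values given here, the series shares a methylene lactone core carrying a carbamate-linked aryl group; the three measured members differ only in the aryl substitution. Compound 1 `C=C1C(=O)OC[C@@H]1CCOC(=O)Nc1ccc(C(C)C)cc1` gives 15300 nM in an ADME assay on RAW264.7 cells (Mus musculus) for cytotoxicity, read by MTT assay, with a stated time of 18 h; on this read-out lower numbers stand for higher toxicity in this test and higher numbers for lower toxicity in this test. Compound 2 `C=C1C(=O)OC[C@@H]1CCOC(=O)Nc1ccccc1F` gives 24200 nM in this assay, the highest of the three numbers recorded, though compound 1 lies within the scatter of it. Compound 3 `C=C1C(=O)OC[C@@H]1CCOC(=O)Nc1ccc(F)cc1F` gives 14800 nM in this assay, and the step of a 1.6-fold lower number from compound 2 to compound 3 (0.21 log units; within the scatter) is within the scatter.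

Compound 4 `C=C1C(=O)OC[C@@H]1CCOC(=O)Nc1ccccc1` has not been measured. It is reached from compound 2 by hydrogen in place of fluoro on an aromatic carbon. Among the compounds with values here, the only measured step that bears on this change is the one from compound 2 to compound 3, where a fluoro entered on an aromatic carbon and the number moved a 1.6-fold lower number from compound 2 to compound 3 (0.21 log units; within the scatter), within the scatter. A single fluoro leaving the aromatic ring is a change of the same kind and size, so no step beyond the scatter is expected in this assay in either direction.

Compound 4 is therefore estimated at 22000 nM in this assay, with a range of 11000 nM to 44000 nM. The expected step from compound 2 is a 1.1-fold lower number from compound 2 to compound 4 (0.04 log units; within the scatter).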

Compound 4, half-maximal cytotoxic concentration: 22300 nM
Estimate against measurement, compound 4: 1.0-fold (0.01 log units) below; the range from low to high includes it.
By their numbers in this assay, from the lowest: compounds 3, 1, 4 and 2 (each within the scatter of the next).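

In this assay, hydrogen in place of fluoro on the aromatic carbon ortho to a large group gives a 1.1-fold lower number from compound 2 to compound 4 (0.04 log units; within the scatter), so this position now has a direct reading of its own, whereas the earlier step concerned a second fluoro entering compound 2. Compound 4 also provides the aryl group with no substituent as a reference, and hydrogen in place of isopropyl gives a 1.5-fold higher number from compound 1 to compound 4 (0.16 log units; within the scatter), which places the isopropyl change within the scatter as well. With a 1.6-fold lower number from compound 2 to compound 3 (0.21 log units; within the scatter) included, all three steps read so far on the aryl group stay within the scatter, so neither fluoro nor isopropyl has yet separated any compound in this series on this read-out. Nothing available bears on why these changes leave the number within the scatter.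

As far as these compounds go, whether an amine or a carboxylic acid on the aromatic ring would give a step beyond the scatter remains open, as does the effect of a longer chain in place of isopropyl. All the compounds shown keep the shared core and its carbamate link, so the effect of a change in either on this read-out is also open.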